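The source may hold more compounds than are shown below. What is called first, only, known or untested is meant among the compounds shown, and "the series" means these compounds.

In a functional assay on A549 cells (Homo sapiens) for inhibition (a higher number here means a weaker inhibitor, a lower number a stronger inhibitor), compound 1, `COc1cc(/C=C/c2ccc3ccccc3c2)cc([N+](=O)[O-])c1OC`, gives > 10000 nM, which is a limit of the assay and not a number. Compound 2, `COc1c([N+](=O)[O-])cc(/C=C/c2ccc3ccccc3c2)cc1[N+](=O)[O-]`, gives > 5000 nM, and this too is only a limit, so compound 2 offers no exact starting point. Compound 3, `CN(C)c1c([N+](=O)[O-])cc(/C=C/c2ccc3ccccc3c2)cc1[N+](=O)[O-]`, differs from compound 2 in one place: dimethylamino in place of methoxy on an aromatic carbon. Among the measured compounds shown here, the one measured step that also replaces a methoxy is a step that the two limits leave unreadable from compound 1 to compound 2, so it offers no size to carry over. For the measured compounds named here, with that step as the only guide, nothing points to a real gain in this assay, and compound 3 is expected to stay a weak inhibitor. The expected change is a step that the limit leaves unreadable from compound 2 to compound 3, with no clear step anticipated. For compound 3 the estimated value is 8000 nM, with an expected range from 1500 nM to 30000 nM.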

Compound 3, half-maximal inhibitory concentration: > 5000 nM
Compound 3 gave a limit, no number; the forecaster's own chance of this, stated with the estimate: 65%; the middle value lies beyond the limit too.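

In this assay compound 3 gives > 5000 nM, which is a limit and not a number. Compound 2 also gives only a limit, so the step between these two compounds cannot be read. The compounds shown leave open whether methoxy or dimethylamino gives the stronger inhibitor.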